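A few compounds are considered here, and "the series" means these few. Any claim that something is new, unique, unknown or untested is made for them only; others in the source may bear on it.

Measured compounds:
compound 1, `CSc1ccc(/C=N/N(C(=O)c2ccccc2)C(=O)c2ccncc2)cc1`, > 100 ug/mL in an ADME assay on HEL cells (Homo sapiens) for cytotoxicity; on this read-out lower numbers stand for higher toxicity in this test and higher numbers for lower toxicity in this test
compound 2, `COc1cc(/C=N/N(C(=O)c2ccccc2)C(=O)c2ccncc2)ccc1O`, > 100 ug/mL in this assay

Both values are limits of the test rather than numbers. For compound 1 the value > 100 ug/mL means that no cytotoxicity was seen up to the highest concentration tested. For compound 2 the value > 100 ug/mL is the same kind of limit. Compound 2 therefore stands at a limit only, and this is true of every value shown, as the limit of > 100 ug/mL in this assay, at which 2 of the 2 values shown sit, records. The step that the two limits leave unreadable from compound 1 to compound 2 cannot be read, since both ends are limits.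

Compound 3, `CCOc1cc(/C=N/N(C(=O)c2ccccc2)C(=O)c2ccncc2)ccc1O`, is not yet measured. It differs from compound 2 by methyl in place of hydrogen on a saturated chain carbon bound to an oxygen on an aromatic ring. Within the data shown here, the only measured step is the unreadable one from compound 1 to compound 2, so no measured change bears on this small extension of the methoxy to an ethoxy.

With nothing to point either way, compound 3 is expected to behave like compound 2, so the step that the limit leaves unreadable from compound 2 to compound 3 is estimated as none beyond the scatter. For compound 3 the expected outcome is 120 ug/mL, within 50 ug/mL to 300 ug/mL, most likely reported again as a limit.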

Compound 3, minimum cytotoxic concentration: > 100 ug/mL
Compound 3: only a limit was reported (the forecaster's own chance of this, stated with the estimate: 80%); the middle value is on the limit's open side.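

In this assay compound 3 gives > 100 ug/mL as a limit of the test, not a number. No new step can be read between compound 2 and compound 3, since both ends are limits: the limit of > 100 ug/mL in this assay, at which 3 of the 3 values shown sit. On these data alone, what stays open is whether compound 1, compound 2 and compound 3 differ at all on this read-out, and which change to the shared core would give a measurable cytotoxic concentration.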